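From a sulfonylhydrazide amide to a plain benzyl amide

The source may report more compounds than this note shows. Statements on the series, on what has been measured and on what is new or still open speak of the compounds shown alone.

For the measured compounds named here, compound 3 `Cc1ccc(S(=O)(=O)NNC(=O)COc2ccc3cc(C(O)(C(F)(F)F)C(F)(F)F)c(O)cc3c2)cc1` is the one member of this set that gives a number rather than a limit in an assay on isolated protein for inhibition of tyrosine-protein phosphatase non-receptor type 13 (Homo sapiens), read by spectrophotometry; on this read-out lower numbers stand for stronger inhibition and higher numbers for weaker inhibition: compound 3 gives 14900 nM. In this assay compound 1 `CCCNC(=O)COc1ccc2cc(C(O)(C(F)(F)F)C(F)(F)F)c(O)cc2c1` reaches only the limit > 20000 nM. Compound 2 `COc1ccc(CNC(=O)COc2ccc3cc(C(O)(C(F)(F)F)C(F)(F)F)c(O)cc3c2)cc1OC` likewise stops at the limit > 20000 nM. The steps of an at least 1.3-fold lower number from compound 1 to compound 3 (0.12 log units; that floor lies within the scatter) and an at least 1.3-fold lower number from compound 2 to compound 3 (0.12 log units; that floor lies within the scatter) are therefore floors rather than sizes, as the limit of > 20000 nM in this assay, at which 2 of the 3 values shown sit, shows. Compound 4 `O=C(COc1ccc2cc(C(O)(C(F)(F)F)C(F)(F)F)c(O)cc2c1)NCc1ccccc1` carries the change (benzyl in place of ((4-methylphenyl)sulfonyl)amino on an amide-type nitrogen). Going by the values given here, no measured step covers this exact exchange; the nearest comparison is compound 2, whose 3,4-dimethoxybenzyl group resembles the benzyl of compound 4 and which sits at its limit in this assay. Compound 4 is therefore expected to move back toward weaker inhibition in this assay, with an estimated step of a 1.7-fold higher number from compound 3 to compound 4 (0.22 log units; within the scatter). Compound 4 is estimated at 25000 nM, between 10000 nM and 60000 nM, and is expected most likely to be reported only as a limit.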

Compound 4, half-maximal inhibitory concentration: > 20000 nM
Compound 4: only a limit was reported; the forecaster's own chance of this, stated with the estimate: 70%; the middle value does not contradict the limit.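

Benzyl in place of ((4-methylphenyl)sulfonyl)amino on the amide-type nitrogen gives an at least 1.3-fold higher number from compound 3 to compound 4 (0.12 log units; that floor lies within the scatter). Compound 4 shows that the plain benzyl group, without the two methoxy groups of compound 2, also reaches only a limit in this assay, and the steps from compound 1 and from compound 2 to compound 4 join two limits and cannot be read. Compound 3 thus remains the only compound with a number, and any reading of this position stays bounded by a single limit: the limit of > 20000 nM in this assay, at which 3 of the 4 values shown sit.

Whether the sulfonyl group or the 4-methylphenyl ring matters in compound 3 stays open, as the compounds shown do not separate them. A methylsulfonylamino or a benzoylamino group on the same amide-type nitrogen, or a carboxylic acid in place of the amide, would address this.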